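This account rests on a few compounds, and the source may have more. Where it says the series, first, only, none or still open, it means among the compounds named here.

Four compounds built on a shared core are considered here: compound 1 `CCOC(=O)/C(=C/c1ccccc1)CN1C(=O)[C@@H](OC)[C@H]1c1ccc(Cl)cc1`, compound 2 `COC(=O)/C(=C/c1ccccc1)CN1C(=O)[C@@H](OC)[C@H]1c1ccc(F)cc1`, compound 3 `CO[C@@H]1C(=O)N(C/C(C#N)=C/c2ccccc2)[C@@H]1c1ccc(Cl)cc1Cl` and compound 4 `COC(=O)/C(=C/c1ccccc1)CN1C(=O)[C@@H](OC)[C@H]1c1cccc(C(F)(F)F)c1`. The first three have been measured in a functional assay on MDA-MB-231 cells (Homo sapiens) for antiproliferative activity, read by MTT assay, with a stated time of 48 h; a higher number here means a weaker inhibitor, a lower number a stronger inhibitor. There, compound 1 gives 11100 nM, compound 2 gives 21800 nM and compound 3 gives 17000 nM. These three numbers lie within the usual scatter of one another, so compound 2 cannot be told apart from compound 1 or compound 3 in this assay.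

Compound 4 keeps the rest of compound 2 but carries 3-(trifluoromethyl)phenyl in place of 4-fluorophenyl on a saturated ring carbon. Among the compounds with values here, no two measured compounds differ in only one place, so the data offer no direct measure of what such a swap does. Within the data shown here, the only guide is the spread of the measured set, whose members differ in more than one place and still stay close, with compound 1 at 11100 nM and compound 3 at 17000 nM. For this reason, no step beyond the scatter is expected in this assay, and no firm direction can be claimed. The estimated 1.4-fold lower number from compound 2 to compound 4 (0.13 log units; within the scatter) is expected to remain within the scatter. For compound 4 the estimate is 16000 nM, with an expected range of 7000 nM to 38000 nM.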

Compound 4, half-maximal inhibitory concentration: 18200 nM
Beside the measured number, compound 4's estimate is 1.1-fold (0.06 log units) below it; the measured number falls inside the stated range.
By their numbers in this assay, from the lowest: compounds 1, 3, 4 and 2 (each within the scatter of the next).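

Within the data shown here, this is the first direct reading of a single change at this position, the saturated ring carbon of the four-membered ring, next to the ring nitrogen: in this assay, 3-(trifluoromethyl)phenyl in place of 4-fluorophenyl gives a 1.2-fold lower number from compound 2 to compound 4 (0.08 log units; within the scatter). The two compounds therefore cannot be told apart in this assay, even though the swap replaces the group carried by the phenyl ring and also moves it to a different place on that ring. No measurement shown bears on the reason for this result.

This single step cannot show whether the new group and its new place on the ring each leave the number undisturbed or whether their separate effects happen to offset one another. It also leaves open how far this position can be varied, since every group shown there is a halogen- or trifluoromethyl-bearing phenyl ring, and an amine or a carboxylic acid on that ring, or a plain methyl group in place of the ring, could give a quite different reading.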